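The compounds below may be only part of what the source reports. "The series", "measured", "known", "first", "only" and "open" are said of these compounds alone.

Working notes on the series. In a functional assay on cells (T-cell line, Homo sapiens) for inhibition (on this read-out higher numbers stand for weaker inhibition and lower numbers for stronger inhibition), compound 1 (`COc1ccc(CCCN2CCC(CCC(c3ccccc3)c3ccccc3)CC2)cc1`) gives 200 nM and compound 2 (`COc1cccc(CCCN2CCC(COC(c3ccccc3)c3ccccc3)CC2)c1`) gives 1500 nM as its reading. Compound 2 therefore stands at the higher number of the two, on the side of weaker inhibition, and the gap lies beyond the scatter. These two compounds differ in more than one place, so the gap cannot be assigned to a single change.

Compound 3 (`CCCCN1CCC(COC(c2ccccc2)c2ccccc2)CC1`) comes from compound 2 through one change (methyl in place of 3-methoxyphenyl on a saturated chain carbon, three bonds along the chain from an amine nitrogen in a ring), with methyl in place of 3-methoxyphenyl on a saturated chain carbon, three bonds along the chain from an amine nitrogen in a ring. Within the data shown here, no measured pair isolates this change, so its size remains a matter of judgement. Both readings so far, compound 1 with 200 nM and compound 2 with 1500 nM as its number, come from compounds that keep an aromatic ring on this chain. A moderate move towards weaker inhibition in this assay is therefore expected, probably beyond the scatter. The estimated change is a 3.3-fold higher number from compound 2 to compound 3 (0.52 log units; beyond the scatter) on the read-out. For compound 3 the expected value is 5000 nM within an estimated range of 1800 nM to 14000 nM for this read-out.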

Compound 3, half-maximal inhibitory concentration: 14000 nM
Compound 3: the middle estimate sits 2.8-fold (0.45 log units) below what was measured; the range from low to high includes it.
By their numbers in this assay, from the lowest: compound 1; then compound 2; then compound 3.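

In this assay, the step is a 9.3-fold higher number from compound 2 to compound 3 (0.97 log units; beyond the scatter), and this gives the series its first reading of a single change: methyl in place of 3-methoxyphenyl on a saturated chain carbon, three bonds along the chain from an amine nitrogen in a ring. At this position, the aromatic group goes with clearly stronger inhibition than the methyl, although the loss does not remove the read-out altogether, as compound 3 still gives a number of 14000 nM. This holds for this one pair only, and nothing available explains the size of the step.

A cyclohexyl or an unsubstituted phenyl in the same place would help separate the contribution of the ring from that of its methoxy group, a question compound 2 and compound 3 cannot answer between them. The gap between compound 1 and compound 2 also remains unassigned, and no step can be read for any other pair, as those compounds differ in more than one place.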